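A few compounds are considered here, and "the series" means these few. Any claim that something is new, unique, unknown or untested is made for them only; others in the source may bear on it.

Three compounds have been measured in a functional assay on PC-3 cells (Homo sapiens) for antiproliferative activity, read by sulforhodamine B assay, with a stated time of 48 h, tested at 50 uM; a higher number here means more inhibition at the concentration tested (going by the name of the read-out), a lower number less inhibition:
Compound 1, `COc1cccc(C(=O)Oc2cc3c(cc2C)[C@@H](C(C)C)CC=C3C)c1`, gives 16.3%.
Compound 2, `CC1=CC[C@H](C(C)C)c2cc(C)c(OC(=O)c3ccc(C)cc3)cc21`, gives 49.6%.
Compound 3, `CC1=CC[C@H](C(C)C)c2cc(C)c(OC(=O)c3ccc([N+](=O)[O-])cc3)cc21`, gives 36.7%.

Compound 3 stands second highest of the three in this assay, above compound 1 and below compound 2. Compound 4, `CC1=CC[C@H](C(C)C)c2cc(C)c(OC(=O)c3ccccc3)cc21`, differs from compound 3 in one place: hydrogen in place of nitro on an aromatic carbon. The step that bears most on this change is a number 12.9 percentage points lower from compound 2 to compound 3 (beyond the scatter), which shows that swapping the group on that aromatic carbon shifts the read-out by a modest amount; the larger steps of a number 33.3 percentage points higher from compound 1 to compound 2 (beyond the scatter) and a number 20.4 percentage points higher from compound 1 to compound 3 (beyond the scatter) exchange the whole aryl group and are less direct guides. Removing the nitro is expected to move the number back toward compound 2, so a modest rise a number 5.3 percentage points higher from compound 3 to compound 4 (within the scatter) is expected. Compound 4 is therefore estimated at 42%, within a range from 25% to 58%.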

Compound 4, a percentage reported as inhibition, at one concentration (the size of the read-out at that concentration, not a potency): 22.5%
Beside the measured number, compound 4's estimate is 19.5 percentage points above it; the measured number lies below the stated range.
By their numbers in this assay, from the lowest: compounds 1 and 4 (each within the scatter of the next); then compound 3; then compound 2.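

Hydrogen at this place is the low point of the series so far, since a group here, whether nitro or methyl, gives a higher number: a number 14.2 percentage points lower from compound 3 to compound 4 (beyond the scatter) and a number 27.1 percentage points lower from compound 2 to compound 4 (beyond the scatter). With a number 6.2 percentage points higher from compound 1 to compound 4 (within the scatter), the 3-methoxyphenyl of compound 1 and the phenyl of compound 4 cannot be told apart. Nothing measured here explains why a group at this place matters.

From the compounds shown here alone, whether an amine or a carboxylic acid at this place would also raise the number remains open, and so does the effect of a methoxy group moved to this place.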